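Aminoacyl sulfamoyl adenosines: side-chain change at the amino acid

The source may hold more compounds than are shown below. What is called first, only, known or untested is meant among the compounds shown, and "the series" means these compounds.

Measured so far:
compound 1, `CC(C)[C@H](N)C(=O)NS(=O)(=O)OC[C@H]1O[C@@H](n2cnc3c(N)ncnc32)[C@H](O)[C@@H]1O` — 5600 nM
compound 2, `CSCC[C@H](N)C(=O)NS(=O)(=O)OC[C@H]1O[C@@H](n2cnc3c(N)ncnc32)[C@H](O)[C@@H]1O` — 500 nM

Compound 2 gives the lowest of the two numbers in a functional assay on PBMC cells (Homo sapiens) for inhibition; a lower number here means a stronger inhibitor, a higher number a weaker inhibitor; its nearest neighbour is compound 1, and the gap is an 11-fold lower number from compound 1 to compound 2 (1.05 log units; beyond the scatter), which exceeds the scatter. For the measured compounds named here, that single step, 2-(methylsulfanyl)ethyl in place of isopropyl on a saturated chain carbon bound to an amine nitrogen and a carbonyl carbon, is the only comparison on record for this series.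

Compound 3, `N=C(N)NCCC[C@H](N)C(=O)NS(=O)(=O)OC[C@H]1O[C@@H](n2cnc3c(N)ncnc32)[C@H](O)[C@@H]1O`, has not been measured. It differs from compound 2 by a group of 5 heavy atoms (2 carbon, 3 nitrogen; no ring) in place of a group of 2 heavy atoms (1 carbon, 1 sulfur; no ring), on a saturated chain carbon, three bonds along the chain from an amine nitrogen and a carbonyl carbon.

Going by the values given here, the only step that bears on this change is the one from compound 1 to compound 2, and it concerns the same side chain; it was large. That shows the side chain matters here, but it does not show in which direction a group of 5 heavy atoms (2 carbon, 3 nitrogen; no ring) will move the number. No step beyond the scatter is therefore asserted, but a wide range is allowed. For compound 3 the step expected is a 3.0-fold higher number from compound 2 to compound 3 (0.48 log units; beyond the scatter). Compound 3 is accordingly estimated at 1500 nM, within a range of 100 nM to 20000 nM.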

Compound 3, half-maximal inhibitory concentration: 1000 nM
Estimate against measurement, compound 3: 1.5-fold (0.18 log units) above; low and high end bracket the measured number.
By their numbers in this assay, from the lowest: compounds 2 and 3 (each within the scatter of the next); then compound 1.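

In this assay, replacing methylsulfanyl with the group of 5 heavy atoms, three bonds along the chain from an amine nitrogen and a carbonyl carbon, gives a 2.0-fold higher number from compound 2 to compound 3 (0.30 log units; within the scatter) and so leaves compound 2 and compound 3 unseparated, although the entering group carries 3 hydrogen-bond donors and the leaving group 0. Against the isopropyl side chain of compound 1, the guanidine-bearing chain gives a 5.6-fold lower number from compound 1 to compound 3 (0.75 log units; beyond the scatter) and so shows that the gain over isopropyl is not confined to the 2-(methylsulfanyl)ethyl chain: two quite different unbranched side chains both sit beyond the scatter from compound 1. No measured evidence is at hand that accounts for these numbers.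

Still open, from the compounds shown here alone, is whether a plain unbranched alkyl chain such as n-butyl would match these two side chains, which would separate the effect of chain shape from that of the sulfur or nitrogen atoms. Also open, going by these compounds, is how a side chain ending in a primary amine, a carboxylic acid or a phenyl ring would fall relative to compound 2 and compound 3.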